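Moving a Methyl Within the Acid Chain

A few compounds are considered here, and "the series" means these few. Any claim that something is new, unique, unknown or untested is made for them only; others in the source may bear on it.

Compound 1 `O=C(O)CCCCc1cccc(OCc2ccc3ccccc3n2)c1`: 100 nM
Compound 2 `CC(CCC(=O)O)Cc1cccc(OCc2ccc3ccccc3n2)c1`: 140 nM

In an assay on membranes from lung (Cavia porcellus) for binding affinity to cysteinyl leukotriene receptor (Homo sapiens) (on this read-out higher numbers stand for weaker inhibition and lower numbers for stronger inhibition), compound 2 holds the higher of the two numbers, with compound 1 nearest, yet the step of a 1.4-fold higher number from compound 1 to compound 2 (0.15 log units; within the scatter) stays within the scatter. Compound 3 `CC(CCCc1cccc(OCc2ccc3ccccc3n2)c1)C(=O)O` shows (3-carboxybutyl in place of 3-carboxy-1-methylpropyl on a saturated chain carbon bound to an aromatic carbon). Among the compounds with values here, the only measured step bears on this change, and it was within the scatter; no measured step moves the methyl between chain carbons, so the step is expected to be a 1.1-fold lower number from compound 2 to compound 3 (0.03 log units; within the scatter), with no direction beyond the scatter. Compound 3 is therefore estimated at 130 nM, within a range from 60 nM to 300 nM.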

Compound 3, inhibition constant: 85 nM
Beside the measured number, compound 3's estimate is 1.5-fold (0.18 log units) above it; measured number inside the range.
By their numbers in this assay, from the lowest: compounds 3, 1 and 2 (each within the scatter of the next).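

In this assay the change to 3-carboxybutyl in place of 3-carboxy-1-methylpropyl on a saturated chain carbon bound to an aromatic carbon gives a 1.6-fold lower number from compound 2 to compound 3 (0.22 log units; within the scatter) and stays within the scatter. With methyl in place of hydrogen on a saturated chain carbon bound to a carbonyl carbon and a saturated chain carbon, the step is a 1.2-fold lower number from compound 1 to compound 3 (0.07 log units; within the scatter) and also lies within the scatter, so neither methyl placement separates these compounds. No evidence is available to explain these numbers. The compounds shown leave open whether an ethyl group at either chain carbon or a longer chain would give a step beyond the scatter. They also leave open the effect of a tetrazole in place of the carboxylic acid.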